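A few compounds are considered here, and "the series" means these few. Any claim that something is new, unique, unknown or untested is made for them only; others in the source may bear on it.

Measured so far in a functional assay on Jurkat cells (Homo sapiens) for cytotoxicity, with a stated time of 72 h; on this read-out lower numbers stand for an effect already at smaller amounts and higher numbers for an effect only at larger amounts of compound:
- compound 1 `C=C[C@@](C)(/C=C/c1ccc(O)c(CO)c1)CCC=C(C)C` gives > 49000 nM
- compound 2 `C=C[C@@](C)(/C=C/c1ccc(O)c(C=O)c1)CCC=C(C)C` gives > 49000 nM
- compound 3 `C=C[C@@](C)(/C=C/c1ccc(O)c(/C=C/C(=O)OCc2ccccc2)c1)CCC=C(C)C` gives > 49000 nM

Each of these entries is a limit of the assay and not a number. Compound 3 stands only at a limit, > 49000 nM, and so gives no exact starting value for the next step. The series as a whole is summed up by the limit of > 49000 nM in this assay, at which 3 of the 3 values shown sit.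

Compound 4 `C=C[C@@](C)(/C=C/c1ccc(O)c(/C=C/C(N)=O)c1)CCC=C(C)C` is the next compound to be read. The change from compound 3 is amino in place of benzyloxy on a carbonyl carbon, or benzyloxycarbonyl to carbamoyl when cut one bond further out.

For the measured compounds named here, only one measured step exists, a step that the two limits leave unreadable from compound 1 to compound 2, and it has no readable size. It is also a different change, formyl in place of hydroxymethyl on an aromatic carbon. Going by the values given here, no measured step covers the exchange at the carbonyl carbon. Among the compounds with values here, no step beyond the scatter is expected in this assay because the limit of > 49000 nM in this assay, at which 3 of the 3 values shown sit, is the only guide, and no direction can be read from it. The expected change is a step that the limit leaves unreadable from compound 3 to compound 4. A further limit is the most likely report. For compound 4 the estimated value is 50000 nM, with an expected range of 20000 nM to 100000 nM.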

Compound 4, half-maximal effective concentration: > 49000 nM
Compound 4 ended at the assay's limit (the forecaster's own chance of this, stated with the estimate: 80%); the middle value does not contradict the limit.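

In this assay compound 4 gives > 49000 nM, which is a limit of the assay. The steps to compound 4 from compound 1, compound 2 and compound 3 cannot be read, and the series is summed up by a single limit: the limit of > 49000 nM in this assay, at which 4 of the 4 values shown sit.

The compounds shown leave open whether any exchange on the shared core gives a measurable value in this read-out.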